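The compounds below may be only part of what the source reports. "The series", "measured", "known", "first", "only" and "open" are said of these compounds alone.

Measured so far:
compound 1 `CC1=C(C(=O)Nc2ccccc2Cl)C(c2cccs2)NC(=O)N1`
compound 2 `CC1=C(C(=O)Nc2cccc(Cl)c2)C(c2cccs2)NC(=O)N1`
compound 3 `CC1=C(C(=O)Nc2ccccc2Cl)C(c2cnc(CS)n2NCc2ccccc2)NC(=O)N1`

In an ADME assay on Vero cells (Chlorocebus sabaeus) for cytotoxicity, read by XTT assay, with a stated time of 72 h (a lower number here means that less compound is tolerated, a higher number that more compound is tolerated), compound 1 gives > 100000 nM, a limit of the assay rather than a number. Compound 2 also stops at the limit > 100000 nM in this assay. Compound 3 likewise reaches only the limit > 100000 nM in this assay.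

Compound 2 differs from compound 1 by 3-chlorophenyl in place of 2-chlorophenyl on an amide-type nitrogen. The step that the two limits leave unreadable from compound 1 to compound 2 cannot be sized because the limit of > 100000 nM in this assay, at which 3 of the 3 values shown sit, covers both ends of it. Compound 4 `CC1=C(C(=O)Nc2cccc(Cl)c2)C(c2cnc(CS)n2NCc2ccccc2)NC(=O)N1` has not been measured; it differs from compound 3 by 3-chlorophenyl in place of 2-chlorophenyl on an amide-type nitrogen, the same change at the same place. The difference between the cores of compound 1 and compound 3 is not broken down here. The expected step in this assay is a number no higher from compound 3 to compound 4 (the limit leaves the size open), set beside the earlier one, and it rests on the fact that (the limit of > 100000 nM in this assay, at which 3 of the 3 values shown sit). Compound 4 is therefore expected to give about 100000 nM.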

Compound 4, half-maximal cytotoxic concentration: > 100000 nM
Compound 4 ended at the assay's limit; the forecaster's own chance of this, stated with the estimate: 90%; the middle value lies on the limit itself.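

No size can be read for the step between compound 3 and compound 4, because both stop at the same limit: the limit of > 100000 nM in this assay, at which 4 of the 4 values shown sit.

The compounds shown leave open at what concentration, if any, each would reach its half-maximal cytotoxic effect in this assay.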